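Acyl side-chain swap on the shared core: compound 4

A few compounds are considered here, and "the series" means these few. Any claim that something is new, unique, unknown or untested is made for them only; others in the source may bear on it.

Compound 1 `Cc1ccc(OCC(=O)N2CCN(c3ccc(C(F)(F)F)cc3[C@@H](N)CC(C)C)CC2)cc1` gives the highest of the three numbers in an assay on HEK293 cells for displacement of a labelled ligand from Melanocortin receptor 4 (Homo sapiens); a lower number here means a stronger inhibitor, a higher number a weaker inhibitor: compound 1 gives 4400 nM. Among the compounds with values here, its nearest neighbour is compound 3 `CC(C)C[C@H](N)c1cc(C(F)(F)F)ccc1N1CCN(C(=O)COc2ccc([N+](=O)[O-])cc2)CC1`, which gives 3100 nM; the only single-point step, a 1.4-fold lower number from compound 1 to compound 3 (0.15 log units; within the scatter), lies within the scatter. Within the data shown here, compound 2 `COc1cc(Cl)ccc1C[C@@H](C)C(=O)N1CCN(c2ccc(C)cc2[C@@H](N)CC(C)C)CC1` gives 8.1 nM, far below compound 1, but it differs in several places at once, so no single step is computed. Compound 4 `COc1ccc(CC(C)C(=O)N2CCN(c3ccc(C(F)(F)F)cc3[C@@H](N)CC(C)C)CC2)cc1F` takes a chain of the same kind as compound 2: 1-(3-fluoro-4-methoxybenzyl)ethyl in place of (4-methylphenoxy)methyl on a carbonyl carbon. Given that compound 2 gives 8.1 nM with such a chain, a large drop is expected, though the remaining differences from compound 2 leave the size uncertain. For compound 4 a value of 30 nM is expected, within 5 nM to 200 nM, meaning an estimated step of a 150-fold lower number from compound 1 to compound 4 (2.17 log units; beyond the scatter).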

Compound 4, inhibition constant: 200 nM
The estimate for compound 4 lay 6.7-fold (0.82 log units) below the measured number; measured number inside the range.
By their numbers in this assay, from the lowest: compound 2; then compound 4; then compounds 3 and 1 (each within the scatter of the next).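

In this assay, the chain on the carbonyl carbon emerges as a strong determinant of the number: the 1-(3-fluoro-4-methoxybenzyl)ethyl chain gives a 22-fold lower number from compound 1 to compound 4 (1.34 log units; beyond the scatter) and also a 16-fold lower number from compound 3 to compound 4 (1.19 log units; beyond the scatter). By contrast, swapping methyl for nitro within the phenoxy chain gave only a 1.4-fold lower number from compound 1 to compound 3 (0.15 log units; within the scatter). Nothing available explains the gain.

Which part of the new chain carries the step remains open, as its fluorine, methoxy and branching methyl entered together. Also open, on these data alone, is how a chain bearing an amine or a carboxylic acid would read at this position.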